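Methylating the Hydroxyl of Compound 2

The source may hold more compounds than are shown below. What is called first, only, known or untested is meant among the compounds shown, and "the series" means these compounds.

Compound 2 `O=C(Nc1ccccc1O)C1c2ccccc2CCN1C(=O)c1ccc(Cl)cc1`: in a functional assay on NUGC-3 cells (Homo sapiens) for inhibition, read by sulforhodamine B assay, with a stated time of 48 h (a higher number here means a weaker inhibitor of growth, a lower number a stronger inhibitor of growth), compound 2 gives > 10000 nM, a limit of the assay.
Compound 1 `O=C(Nc1cccc(C(F)(F)F)c1)C1c2ccccc2CCN1C(=O)c1ccc(Cl)cc1`: in this assay compound 1 gives > 10000 nM, also a limit.
Compound 3 `O=C(Nc1ccc(C(F)(F)F)cc1)C1NCCc2ccccc21`: in this assay compound 3 gives 4220 nM.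

Compound 2 stands at the limit where two of the three values sit (the limit of > 10000 nM in this assay, at which 2 of the 3 values shown sit). Going by the values given here, the only step between measured compounds, a step that the two limits leave unreadable from compound 1 to compound 2, gives no readable size. Compound 4 `COc1ccccc1NC(=O)C1c2ccccc2CCN1C(=O)c1ccc(Cl)cc1` carries methyl in place of hydrogen on an oxygen on an aromatic ring. Among the compounds with values here, no measured step involves methyl in place of hydrogen on an oxygen on an aromatic ring, so none bears on this change; the expectation rests on compound 2 alone. Compound 4 is therefore expected to remain near the limit in this assay, estimated at 15000 nM with a range from 4000 nM to 60000 nM. This estimate means a step that the limit leaves unreadable from compound 2 to compound 4 that is not expected to exceed the scatter.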

Compound 4, concentration for 50% growth inhibition: 1590 nM
The estimate for compound 4 lay 9.4-fold (0.97 log units) above the measured number, and the stated range ends above it.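

On the shared core, the oxygen of the 2-hydroxyphenyl group proves to be a position where a small change can be read in this assay: methyl in place of hydrogen gives an at least 6.2-fold lower number from compound 2 to compound 4 (0.79 log units; beyond the scatter). Changing the amide's aromatic group also matters, as 2-methoxyphenyl in place of 3-(trifluoromethyl)phenyl gives an at least 6.2-fold lower number from compound 1 to compound 4 (0.79 log units; beyond the scatter). The full size of both steps stays unknown, as each starts from a limit of the assay: the limit of > 10000 nM in this assay, at which 2 of the 4 values shown sit.

On these data alone, whether an ethyl group or a longer chain on this oxygen keeps the gain remains open. So does the effect of an amine in place of the methoxy group.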